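Swapping the benzyl group on compound 3 for a cyanobenzyl

The compounds below may be only part of what the source reports. "The series", "measured", "known", "first", "only" and "open" are said of these compounds alone.

Measured so far:
- Compound 1 `O=c1ccoc2cc(OCc3cn(Cc4ccc(Cl)cc4)nn3)ccc12` gives > 100000 nM in a functional assay on A549 cells (Homo sapiens) for cytotoxicity, read by MTT assay, with a stated time of 48 h; a higher number here means a weaker inhibitor, a lower number a stronger inhibitor; this value is a limit of the assay.
- Compound 2 `O=c1ccoc2cc(OCc3cn(Cc4ccc(Cl)cc4Cl)nn3)ccc12` gives 5260 nM in this assay.
- Compound 3 `O=c1ccoc2cc(OCc3cn(Cc4ccccc4Cl)nn3)ccc12` gives > 100000 nM in this assay; this value is also a limit of the assay.

Compound 3 therefore sits at the limit, as shown in the limit of > 100000 nM in this assay, at which 2 of the 3 values shown sit, so no number is known for it. Compound 4 `N#Cc1ccc(Cn2cc(COc3ccc4c(=O)ccoc4c3)nn2)cc1` differs from compound 3 in one place: 4-cyanophenyl in place of 2-chlorophenyl on a saturated chain carbon bound to an aromatic nitrogen.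

Two measured steps are readable: an at least 19-fold lower number from compound 1 to compound 2 (1.27 log units; beyond the scatter) and an at least 19-fold higher number from compound 2 to compound 3 (1.27 log units; beyond the scatter). Both concern a chloro group; neither concerns a nitrile. The remaining step, a step that the two limits leave unreadable from compound 1 to compound 3, is unreadable because both ends are limits. So no measured step bears directly on the change from compound 3 to compound 4, and the only comparable pair, compound 1 and compound 3, both stayed at the limit when the benzyl group was changed.

Compound 4 is therefore expected to stay near the limit as well, a step of a number no higher from compound 3 to compound 4 (the limit leaves the size open). The estimate for compound 4 is 100000 nM, within 20000 nM to 300000 nM.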

Compound 4, half-maximal inhibitory concentration: > 100000 nM
Compound 4 gave a limit, no number (the forecaster's own chance of this, stated with the estimate: 70%); the middle value sits exactly at the limit.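

Among the compounds shown here, compound 4 brings a nitrile to this position, a group that none of the earlier compounds carried, and 4-cyanophenyl does not match 2,4-dichlorophenyl in this assay: the change gives an at least 19-fold higher number from compound 2 to compound 4 (1.27 log units; beyond the scatter). Compound 4 gives only a limit, so the steps to it from compound 1 and from compound 3 have a limit at both ends and cannot be read. Compound 2 thus remains the only compound here with a number, while the 2-chlorophenyl, 4-chlorophenyl and 4-cyanophenyl groups all leave the value at a limit: the limit of > 100000 nM in this assay, at which 3 of the 4 values shown sit.

From the compounds shown here alone, how far these three compounds lie past that limit stays unknown, so the chloro and nitrile groups cannot be ranked against each other. Also open, going by these compounds, is whether a methoxy group or an amine on the ring, alongside the 4-chloro group, would give a measurable number as the second chloro of compound 2 does.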